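The source may report more compounds than this note shows. Statements on the series, on what has been measured and on what is new or still open speak of the compounds shown alone.

Series to date:
compound 1, `CCCCCCCCCCn1cc(Cn2nc(N)c3c(C(F)(F)F)cc(-c4ccccc4)nc32)nn1`, a functional assay on THP-1 cells (Homo sapiens) for cytotoxicity, read by MTT assay, with a stated time of 24 h (a lower number here means a stronger inhibitor, a higher number a weaker inhibitor), 48.7 ug/mL
compound 2, `COc1ccc(NC(=O)Cn2cc(Cn3nc(N)c4c(C(F)(F)F)cc(-c5ccccc5)nc43)nn2)cc1`, this assay 56.7 ug/mL
compound 3, `Nc1nn(Cc2cn(CC(=O)Nc3ccc(F)cc3)nn2)c2nc(-c3ccccc3)cc(C(F)(F)F)c12`, this assay 49.6 ug/mL

Compound 3 stands second of the three numbers, with compound 1 the nearest and compound 2 the furthest, both within the scatter. Compound 4 is `Nc1nn(Cc2cn(CC(=O)Nc3cccc(Cl)c3)nn2)c2nc(-c3ccccc3)cc(C(F)(F)F)c12`; the change from compound 3 is 3-chlorophenyl in place of 4-fluorophenyl on an amide-type nitrogen. Going by the values given here, the one measured step that bears on it, an exchange of a substituent on the same aromatic ring, is a 1.1-fold lower number from compound 2 to compound 3 (0.06 log units; within the scatter), within the scatter, and the larger exchanges a 1.2-fold higher number from compound 1 to compound 2 (0.07 log units; within the scatter) and a 1.0-fold higher number from compound 1 to compound 3 (0.01 log units; within the scatter) also stayed flat. No step beyond the scatter is therefore expected. Compound 4 is estimated at 50 ug/mL, range 30 ug/mL to 85 ug/mL. The expected step is a 1.0-fold higher number from compound 3 to compound 4 (0.00 log units; within the scatter).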

Compound 4, half-maximal inhibitory concentration: 37 ug/mL
Compound 4: middle estimate off by 1.4-fold (0.13 log units), on the high side; low and high end bracket the measured number.
By their numbers in this assay, from the lowest: compounds 4, 1, 3 and 2 (each within the scatter of the next).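

In this assay the 3-chlorophenyl group on the amide-type nitrogen gives a 1.3-fold lower number from compound 3 to compound 4 (0.13 log units; within the scatter) and a 1.5-fold lower number from compound 2 to compound 4 (0.19 log units; within the scatter) as well as a 1.3-fold lower number from compound 1 to compound 4 (0.12 log units; within the scatter) with no step beyond the scatter. A chlorine-bearing ring therefore joins 4-fluorophenyl, 4-methoxyphenyl and the nonyl chain as a change at this position that leaves the number flat. No measurement at hand accounts for these numbers.

Open, from the compounds shown here alone, is whether an amine or a carboxylic acid on this aryl ring would give a step beyond the scatter. Also open, going by these compounds, is what replacing the trifluoromethyl group on the shared core would do.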